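Swapping chloro for fluoro on a benzylidene arm

The source may report more compounds than this note shows. Statements on the series, on what has been measured and on what is new or still open speak of the compounds shown alone.

Of the compounds shown here, three sharing one core have been tested in a functional assay on MCF7 cells (Homo sapiens) for cytotoxicity, read by sulforhodamine B assay, with a stated time of 48 h; a lower number here means a stronger inhibitor, a higher number a weaker inhibitor. Compound 1 `COc1ccc(C2C(C#N)=C(N)Oc3nc(Nc4ccc(S(N)(=O)=O)cc4)sc32)cc1` gives 27500 nM. Compound 2 `COc1ccc(C2C(C#N)=C(/N=C/c3ccccc3Cl)Oc3nc(Nc4ccc(S(N)(=O)=O)cc4)sc32)cc1` gives 10300 nM, and compound 3 `COc1ccc(C2C(C#N)=C(/N=C/c3ccc(Cl)cc3)Oc3nc(Nc4ccc(S(N)(=O)=O)cc4)sc32)cc1` gives 9550 nM. Among these numbers compound 3 stands lowest, although the step of a 1.1-fold lower number from compound 2 to compound 3 (0.03 log units; within the scatter) lies within the scatter, so compound 2 and compound 3 cannot be ranked against each other. The steps of a 2.7-fold lower number from compound 1 to compound 2 (0.43 log units; beyond the scatter) and a 2.9-fold lower number from compound 1 to compound 3 (0.46 log units; beyond the scatter) are modest but beyond the scatter.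

Compound 4 `COc1ccc(C2C(C#N)=C(/N=C/c3ccc(F)cc3)Oc3nc(Nc4ccc(S(N)(=O)=O)cc4)sc32)cc1` differs from compound 3 by fluoro in place of chloro on an aromatic carbon, a change read one bond further out as 4-chlorophenyl to 4-fluorophenyl. For the measured compounds named here, no measured step swaps one halogen for another; the only step on this arm, a 1.1-fold lower number from compound 2 to compound 3 (0.03 log units; within the scatter), moves the chloro group and changes nothing beyond the scatter. For compound 4 a step of a 1.2-fold higher number from compound 3 to compound 4 (0.06 log units; within the scatter) is therefore expected, meaning no change beyond the scatter. Compound 4 is estimated at 11000 nM, in a range from 4500 nM to 27000 nM.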

Compound 4, half-maximal inhibitory concentration: 28900 nM
Compound 4: the middle estimate sits 2.6-fold (0.42 log units) below what was measured; measured number above the stated range.
By their numbers in this assay, from the lowest: compounds 3 and 2 (each within the scatter of the next); then compounds 1 and 4 (each within the scatter of the next).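

In this assay the identity of the halogen matters at this position, para to a large group: fluoro in place of chloro gives a 3.0-fold higher number from compound 3 to compound 4 (0.48 log units; beyond the scatter) as a modest loss, whereas moving the chloro group changed nothing beyond the scatter. The 4-fluorophenyl arm also falls short of the 2-chlorophenyl arm, with a 2.8-fold higher number from compound 2 to compound 4 (0.45 log units; beyond the scatter) as a modest step. Adding an aromatic arm therefore brings no gain by itself, since a 1.1-fold higher number from compound 1 to compound 4 (0.02 log units; within the scatter) leaves the fluoro compound level with the parent amine, while both chloro compounds stand beyond the scatter from it.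

Nothing available here explains this gap between chloro and fluoro. From the compounds shown here alone, whether bromo, methyl or an amine at the same place would match chloro or fluoro remains open.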